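This account rests on a few compounds, and the source may have more. Where it says the series, first, only, none or still open, it means among the compounds named here.

The study measures cytotoxicity in a functional assay on L1210 cells (Mus musculus) for cytotoxicity; on this read-out higher numbers stand for weaker inhibition and lower numbers for stronger inhibition. Compound 1 `Cc1cn([C@@H]2O[C@@H]3COP(=O)(O)O[C@H]3[C@H]2O)c(=O)nc1N` carries a methyl on the shared core. In this assay compound 1 gives > 200 ug/mL, which is a limit of the assay rather than a number. Compound 2 `CCCCCc1cn([C@@H]2O[C@@H]3CO[PH](O)(O)O[C@H]3[C@H]2O)c(=O)nc1N` is a close relative. In this assay compound 2 gives > 200 ug/mL, again a limit and not a number. Compound 3 `CCCc1cn([C@@H]2O[C@@H]3CO[PH](O)(O)O[C@H]3[C@H]2O)c(=O)nc1N` differs from compound 2 in one place. In this assay compound 3 gives > 200 ug/mL, also a limit. The step that the two limits leave unreadable from compound 2 to compound 3 therefore shows no readable size. Compound 4 `CC(C)c1cn([C@@H]2O[C@@H]3COP(=O)(O)O[C@H]3[C@H]2O)c(=O)nc1N` differs from compound 1 in one place: isopropyl in place of methyl on an aromatic carbon. For the measured compounds named here, the only evidence that bears on this change is the limit of > 200 ug/mL in this assay, at which 3 of the 3 values shown sit, so no measured step gives a direction or a size for it. Because every measured value sits at the limit of > 200 ug/mL in this assay, at which 3 of the 3 values shown sit, compound 4 is expected to stay near that limit, and its value in this assay is estimated at 300 ug/mL, with a range from 100 ug/mL to 1000 ug/mL. The expected step that the limit leaves unreadable from compound 1 to compound 4 is estimated as nothing beyond the scatter.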

Compound 4, concentration for 50% inhibition: > 200 ug/mL
Compound 4 gave a limit, no number; the forecaster's own chance of this, stated with the estimate: 85%; the middle value does not contradict the limit.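

In this assay compound 1 and compound 4 both give only a limit of the assay and not a number, so the change from methyl to isopropyl yields no readable step: the limit of > 200 ug/mL in this assay, at which 4 of the 4 values shown sit. The compounds shown leave open how strongly any of them inhibits these cells, and whether any change on the shared core alters that.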